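Moving one methoxy group on the dimethoxyphenyl ring

The source may hold more compounds than are shown below. What is called first, only, known or untested is meant among the compounds shown, and "the series" means these compounds.

compound 1 `COc1ccc(/C=C/C(=O)/C=C/c2cc3ccccc3nc2Cl)c(OC)c1`: > 10000 nM
compound 2 `COc1ccc(/C=C/C(=O)/C=C/c2cc3ccccc3nc2Oc2ccc(Br)cc2)c(OC)c1`: > 10000 nM

In a functional assay on NCI-H460 cells (Homo sapiens) for cytotoxicity, read by MTT assay, with a stated time of 48 h (a higher number here means a weaker inhibitor, a lower number a stronger inhibitor), compound 2 gives > 10000 nM, which is a limit and not a number. Compound 1 gives > 10000 nM, which is also a limit. Going by these compounds, both compounds therefore sit at the limit of > 10000 nM in this assay, at which 2 of the 2 values shown sit, so the true standing of compound 2 is unknown.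

Compound 3 `COc1ccc(/C=C/C(=O)/C=C/c2cc3ccccc3nc2Oc2ccc(Br)cc2)cc1OC` differs from compound 2 by one change, 3,4-dimethoxyphenyl in place of 2,4-dimethoxyphenyl on a double-bonded chain carbon bound to a double-bonded chain carbon.

Among the compounds with values here, the only measured step, a step that the two limits leave unreadable from compound 1 to compound 2, involves a different change and has no readable size. It offers no size or direction to carry over, so only a cautious expectation is possible in this assay. The expected change is an at least 1.1-fold lower number from compound 2 to compound 3 (0.04 log units; that floor lies within the scatter). For compound 3 the estimate is 9000 nM, with an expected range from 2000 nM to 20000 nM.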

Compound 3, half-maximal inhibitory concentration: > 10000 nM
Compound 3: a limit, no number; the forecaster's own chance of this, stated with the estimate: 55%; at least 1.1-fold (0.04 log units) between middle value and limit.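

Compound 3 gives only a limit, as compound 2 does, so the step between them cannot be read and has neither size nor direction: the limit of > 10000 nM in this assay, at which 3 of the 3 values shown sit.

Going by these compounds, how strongly compound 1, compound 2 and compound 3 act on these cells stays open, as does any difference between 2,4-dimethoxyphenyl and 3,4-dimethoxyphenyl.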